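Replacing 1H-imidazol-4-yl with nitro on a shared core

The source may report more compounds than this note shows. Statements on the series, on what has been measured and on what is new or still open speak of the compounds shown alone.

Compound 1 `COc1cc(OC)c(OC)cc1/C=C/C(=O)c1ccc(-c2c[nH]cn2)cc1` gives > 150000 nM
Compound 2 `COc1cc(OC)c(OC)cc1/C=C/C(=O)c1ccc(O)cc1O` gives 33800 nM
Compound 3 `COc1cc(OC)c(OC)cc1/C=C/C(=O)c1ccc(Cl)c([N+](=O)[O-])c1` gives 16400 nM

All three compounds were tested in a functional assay on MCF7 cells (Homo sapiens) for inhibition, read by MTT assay, with a stated time of 72 h (a lower number here means a stronger inhibitor, a higher number a weaker inhibitor), and share one core. Compound 1 gives > 150000 nM as a limit of the assay, not a number. Compound 1 thus sits at the limit of > 150000 nM in this assay, at which 1 of the 3 values shown sits, and has no exact place on the scale. Compound 2 at 33800 nM and compound 3 at 16400 nM both give numbers.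

The step followed here leads to compound 4 `COc1cc(OC)c(OC)cc1/C=C/C(=O)c1ccc([N+](=O)[O-])cc1` and puts nitro in place of 1H-imidazol-4-yl on an aromatic carbon. No measured pair of these compounds differs in one place only, so no direct precedent sizes this change. The nearest guide is compound 3 at 16400 nM as it also carries nitro. A clear move toward stronger inhibition is therefore expected, with an estimated step of an at least 6.0-fold lower number from compound 1 to compound 4 (0.77 log units; beyond the scatter) in this direction. The starting point of that step is only a limit, so its size is loose. Compound 4 is expected at 25000 nM in this assay with an estimated range from 9000 nM to 70000 nM for its reading.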

Compound 4, half-maximal inhibitory concentration: > 150000 nM
Compound 4: a limit, no number; the forecaster's own chance of this, stated with the estimate: 15%; middle value at least 6.0-fold (0.77 log units) away from the limit.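

In this assay compound 4 gives > 150000 nM as a limit, not a number. Among these compounds, compound 1 is also a limit, so no step between compound 1 and compound 4 can be read: the limit of > 150000 nM in this assay, at which 2 of the 4 values shown sit. The compounds shown leave open how nitro in place of 1H-imidazol-4-yl changes the reading, since neither compound has an exact place on the scale.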